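Compound 4: bromo and methoxy on the hydroxyphenyl group

The source may hold more compounds than are shown below. What is called first, only, known or untested is meant among the compounds shown, and "the series" means these compounds.

In a functional assay on SW480 cells (Homo sapiens) for antiproliferative activity, read by sulforhodamine B assay, with a stated time of 48 h (on this read-out higher numbers stand for weaker inhibition and lower numbers for stronger inhibition), compound 1 (`COc1cc(C=C(C(=O)/C=C/c2cccc(OC)c2OC)C(=O)/C=C/c2cccc(OC)c2OC)ccc1O`) gives 430 nM, compound 2 (`COc1cc(OC)c(/C=C/C(=O)C(=Cc2ccc(O)c(OC)c2)C(=O)/C=C/c2c(OC)cc(OC)cc2OC)c(OC)c1`) gives 1490 nM and compound 3 (`COc1cc(OC)c(/C=C/C(=O)C(=Cc2ccc(O)c(F)c2)C(=O)/C=C/c2c(OC)cc(OC)cc2OC)c(OC)c1`) gives 1950 nM. Compound 3 thus stands level with compound 2, and compound 1 has the lower number than both. Compound 4 (`COc1cc(OC)c(/C=C/C(=O)C(=Cc2cc(Br)c(O)c(OC)c2)C(=O)/C=C/c2c(OC)cc(OC)cc2OC)c(OC)c1`) brings 3-bromo-4-hydroxy-5-methoxyphenyl in place of 3-fluoro-4-hydroxyphenyl on a double-bonded chain carbon bound to a double-bonded chain carbon. Going by the values given here, the one measured step bearing on this is a 1.3-fold higher number from compound 2 to compound 3 (0.12 log units; within the scatter), fluoro in place of methoxy on an aromatic carbon, here partly run in reverse. Among the compounds with values here, no measured compound carries bromo, so that part rests on no data and widens the range. The expected change is small and without a firm direction, a 1.1-fold lower number from compound 3 to compound 4 (0.06 log units; within the scatter), nothing beyond the scatter. The estimate for compound 4 is 1700 nM, with an expected range of 800 nM to 3600 nM.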

Compound 4, half-maximal inhibitory concentration: 1450 nM
The estimate for compound 4 lay 1.2-fold (0.07 log units) above the measured number, and the stated range covers the measured number.
By their numbers in this assay, from the lowest: compound 1; then compounds 4, 2 and 3 (each within the scatter of the next).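

Adding bromo to the hydroxyphenyl group of compound 2 gives no step beyond the scatter in this assay (a 1.0-fold lower number from compound 2 to compound 4 (0.01 log units; within the scatter)). The whole exchange of 3-fluoro-4-hydroxyphenyl for 3-bromo-4-hydroxy-5-methoxyphenyl also stays within the scatter (a 1.3-fold lower number from compound 3 to compound 4 (0.13 log units; within the scatter)), so this group tolerates a larger halogen as well as fluoro and methoxy without a readable shift. No measurement at hand explains this flat result.

Open, going by these compounds, is whether an amine or a carboxylic acid in place of the bromo would move the number beyond the scatter.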